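This account rests on a few compounds, and the source may have more. Where it says the series, first, only, none or still open, it means among the compounds named here.

Measured compounds in an ADME assay (liver) for pharmacokinetics, with Liver microsome (Rattus norvegicus) as the target, using microsomes; on this read-out higher numbers stand for a longer-lived compound and lower numbers for a shorter-lived compound:
- Compound 1, `CCOc1cc(NC(=O)C2(NC(=O)c3ccc4c(C5CCCC5)c(-c5ncc(Cl)cn5)n(C)c4c3)CCC2)ccc1/C=C/C(=O)OC(=O)C[C@H](O)C(=O)O`: compound 1 gives 7.92 h
- Compound 2, `CCOc1cc(NC(=O)C2(NC(=O)c3ccc4c(C5CCCC5)c(-c5ncc(Cl)cn5)n(C)c4c3)CCC2)ccc1/C=C/C(=O)OCOP(=O)(O)O`: compound 2 gives 0.15 h
- Compound 3, `CCOc1cc(NC(=O)C2(NC(=O)c3ccc4c(C5CCCC5)c(-c5ncc(Cl)cn5)n(C)c4c3)CCC2)ccc1/C=C/C(=O)OCC(N)=O`: compound 3 gives 0.383 h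

Compound 2 sits at the bottom of the three numbers in this assay; its nearest neighbour is compound 3, which lies a 2.6-fold higher number from compound 2 to compound 3 (0.41 log units; beyond the scatter), and the furthest is compound 1, from which compound 2 is reached by a 53-fold lower number from compound 1 to compound 2 (1.72 log units; beyond the scatter).

Compound 4, `CCOc1cc(NC(=O)C2(NC(=O)c3ccc4c(C5CCCC5)c(-c5ncc(Cl)cn5)n(C)c4c3)CCC2)ccc1/C=C/C(=O)OCC(=O)N1CCOCC1`, has not yet been measured in this assay. Relative to compound 2 the change is a group of 8 heavy atoms (5 carbon, 1 nitrogen, 2 oxygen; one six-membered non-aromatic ring with 2 hetero atoms) in place of a group of 5 heavy atoms (4 oxygen, 1 phosphorus; no ring), on a saturated chain carbon bound to an oxygen next to a carbonyl group.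

The step that bears most directly on this is a 2.6-fold higher number from compound 2 to compound 3 (0.41 log units; beyond the scatter), where the same group of 5 heavy atoms left the same position and a small carbonyl-bearing group entered. The step of a 21-fold lower number from compound 1 to compound 3 (1.32 log units; beyond the scatter) and the step of a 53-fold lower number from compound 1 to compound 2 (1.72 log units; beyond the scatter) show that the group on this oxygen moves the number over a wide span in this assay, with compound 2 at the low end. Compound 4 carries a carbonyl-bearing group at the same place as compound 3, so a modest rise from compound 2, of about the size seen for compound 3, is the expectation rather than a return toward compound 1.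

For compound 4 the expected number in this assay is 0.4 h, in the range 0.15 h to 1.1 h, which means an expected step of a 2.7-fold higher number from compound 2 to compound 4 (0.43 log units; beyond the scatter).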

Compound 4, half-life: 0.733 h
Compound 4: the middle estimate sits 1.8-fold (0.26 log units) below what was measured; the measured number falls inside the stated range.
By their numbers in this assay, from the lowest: compound 2; then compounds 3 and 4 (each within the scatter of the next); then compound 1.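

In this assay, (morpholin-4-yl)carbonyl on a saturated chain carbon bound to an oxygen next to a carbonyl group also stands clear of the group of 5 heavy atoms in compound 2 (a 4.9-fold higher number from compound 2 to compound 4 (0.69 log units; beyond the scatter)), so this rise is no longer tied to the amino-bearing group alone, while morpholin-4-yl in place of amino on a carbonyl carbon stays within the scatter (a 1.9-fold higher number from compound 3 to compound 4 (0.28 log units; within the scatter)) and the ring gives no readable difference from the smaller group. With the larger group a large gap also remains (an 11-fold lower number from compound 1 to compound 4 (1.03 log units; beyond the scatter)), so neither of the two amide-type groups shown at this place reaches the number of the (2-carboxy-2-hydroxyethyl)carbonyl compound. No supporting data bear on why these groups differ.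

Going by these compounds, whether dimethylamino or piperazin-1-yl on the same carbonyl carbon would stay level with compound 3 and compound 4 remains open. Also open, on these data alone, is whether a longer chain between the oxygen and that carbonyl would shift the number toward compound 2 or toward compound 1.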